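The source may hold more compounds than are shown below. What is called first, only, known or untested is meant among the compounds shown, and "the series" means these compounds.

Working notes on the series.

Three compounds have numbers in an ADME assay on L6 cells (Rattus norvegicus) for cytotoxicity, read by resazurin assay, with a stated time of 70 h; on this read-out higher numbers stand for weaker inhibition and lower numbers for stronger inhibition. Compound 1 `c1ccc(OCCCOc2ccc(-c3cc4cc(C5=NCCN5)ccc4o3)cc2)cc1` gives 10300 nM. Compound 2 `N=C(N)c1ccc2oc(-c3ccc(OCCCCOc4ccccc4)cc3)cc2c1` gives 1300 nM. Compound 3 `CC(C)NC(=N)c1ccc2oc(-c3ccc(OCCCCOc4ccccc4)cc3)cc2c1` gives 6900 nM. On these numbers compound 3 stands second highest: compound 1 sits within the scatter of it, and compound 2 lies beyond the scatter below it. Going by the values given here, the one measured step that differs in a single place is a 5.3-fold higher number from compound 2 to compound 3 (0.72 log units; beyond the scatter), isopropyl in place of hydrogen on an amine nitrogen.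

Compound 4 `c1ccc(OCCCCOc2ccc(-c3cc4cc(C5=NCCN5)ccc4o3)cc2)cc1` is not yet measured in this assay. It differs from compound 3 by a group of 5 heavy atoms (3 carbon, 2 nitrogen; one five-membered non-aromatic ring with 2 hetero atoms) in place of a group of 6 heavy atoms (4 carbon, 2 nitrogen; no ring), on an aromatic carbon. Among the compounds with values here, no measured step covers this exchange. Compound 1 carries the same entering ring with a shorter linker, and its number and that of compound 3 lie within the scatter of each other, so the two values show no separation to build on. The step from compound 2 to compound 3 concerns the leaving group only and does not reach the entering ring.

With nothing pointing either way, no step beyond the scatter is expected in this assay; compound 4 is estimated at 9000 nM, range 4000 nM to 20000 nM, which is expected to mean a 1.3-fold higher number from compound 3 to compound 4 (0.12 log units; within the scatter).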

Compound 4, half-maximal inhibitory concentration: 2900 nM
Compound 4: middle estimate off by 3.1-fold (0.49 log units), on the high side, and the stated range ends above it.
By their numbers in this assay, from the lowest: compound 2; then compound 4; then compounds 3 and 1 (each within the scatter of the next).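

The group on the aromatic carbon now has a measured effect in this assay: with the rest of the structure held, the five-membered non-aromatic ring with 2 hetero atoms gives a 2.4-fold lower number from compound 3 to compound 4 (0.38 log units; beyond the scatter) against the group of 6 heavy atoms and a 2.2-fold higher number from compound 2 to compound 4 (0.35 log units; beyond the scatter) against the other open-chain group. Its number therefore falls inside the span set by the two open-chain groups, so the ring is neither the highest nor the lowest of the three groups compared on this linker. The chain matters as well, since phenoxymethyl in place of phenoxy, with the ring group held, gives a 3.6-fold lower number from compound 1 to compound 4 (0.55 log units; beyond the scatter), and nothing available explains any of these steps.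

On these data alone, whether the chain step carries over to the open-chain groups remains open, since it rests on a single pair of compounds carrying the ring group. Also open, as far as these compounds go, is how a longer chain would read at the saturated chain carbon, or a six-membered non-aromatic ring with two nitrogens on the aromatic carbon.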